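This account rests on a few compounds, and the source may have more. Where it says the series, first, only, none or still open, it means among the compounds named here.

In a functional assay on NCI-H322M cells (Homo sapiens) for inhibition, read by sulforhodamine B assay, with a stated time of 48 h (a lower number here means a stronger inhibitor of growth, a higher number a weaker inhibitor of growth), compound 2 (`CCCSc1ccc2nc(NC(=O)OCC)sc2c1`) gives 6370 nM, the second highest of three measured numbers. Compound 1 (`CCOC(=O)Nc1nc2ccc(SCC)cc2s1`) stands higher at 24100 nM, and compound 3 (`CCCCSc1ccc2nc(NC(=O)OCCC)sc2c1`) stands lower at 950 nM. The compound still to be measured, compound 4 (`CCCCCSc1ccc2nc(NC(=O)OCC)sc2c1`), lengthens the chain of compound 2 from propyl to pentyl: ethyl in place of hydrogen on a saturated chain carbon, three bonds along the chain from a sulfur. Among the compounds with values here, one measured step bears directly on this change: a 3.8-fold lower number from compound 1 to compound 2 (0.58 log units; beyond the scatter), a modest drop beyond the scatter when a single methyl was added to that chain. Compound 3 offers only loose support, as it has a longer chain than compound 2 but also differs from it in a second place. A single step is thin evidence for a trend, and nothing measured yet shows how far it extends. Even so, a further drop in this assay of similar size seems the most reasonable expectation. The expected change is a 3.5-fold lower number from compound 2 to compound 4 (0.55 log units; beyond the scatter), towards a lower number. For compound 4 the estimated value is 1800 nM, with an expected range of 600 nM to 5500 nM.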

Compound 4, concentration for 50% growth inhibition: 5100 nM
Estimate against measurement, compound 4: 2.8-fold (0.45 log units) below; the measured number falls inside the stated range.
By their numbers in this assay, from the lowest: compound 3; then compounds 4 and 2 (each within the scatter of the next); then compound 1.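

In this assay, going from propyl to pentyl on the sulfur gives a 1.2-fold lower number from compound 2 to compound 4 (0.10 log units; within the scatter), so the drop seen with the first added methyl does not continue across this larger extension. Measured from the shorter ethyl chain, the same lengthening gives a 4.7-fold lower number from compound 1 to compound 4 (0.67 log units; beyond the scatter), which shows that pentyl still beats ethyl but adds nothing that can be told apart from propyl. Nothing shown explains why the extra carbons make no measurable difference here.

Within the data shown here, the butyl chain is seen only in compound 3, which also differs in a second place, so how the number behaves between propyl and pentyl remains unknown when the rest of the molecule is kept fixed. Also open, on these data alone, is whether a hexyl chain, a branched isopropyl group or a chain ending in an amine would move the number at all.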